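Bromo for methylamino on the shared core

The compounds below may be only part of what the source reports. "The series", "measured", "known", "first", "only" and "open" are said of these compounds alone.

On these data alone, the set holds three measured compounds and one still open. In a functional assay on KB cells (Homo sapiens) for inhibition (on this read-out higher numbers stand for weaker inhibition and lower numbers for stronger inhibition), compound 1 `Nc1nc2cc(Cl)c(Cl)cc2n1COCCO` gives > 100000 nM, which is a limit of the assay and not a number. Compound 3 `OCCOCn1cnc2c(Cl)c(Cl)ccc21` gives > 100000 nM in this assay, again a limit rather than a number. Compound 2 `CNc1nc2c(Cl)cc(Cl)cc2n1COCCO` stands at > 100000 nM in this assay, also a limit, so no number places it against the others. What remains is the limit of > 100000 nM in this assay, at which 3 of the 3 values shown sit. Going by the values given here, no step between measured compounds is known. Compound 4 `OCCOCn1c(Br)nc2c(Cl)cc(Cl)cc21` differs from compound 2 by bromo in place of methylamino on an aromatic carbon. Among the compounds with values here, with every measured value a limit, no measured step guides the size of this change; the expected step is a step that the limit leaves unreadable from compound 2 to compound 4, none beyond the scatter, with the open chance of a real number appearing. Compound 4 is therefore estimated at 150000 nM in this assay, within 30000 nM to 1000000 nM, and most likely reported once more only as a limit.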

Compound 4, half-maximal inhibitory concentration: > 100000 nM
Compound 4 gave a limit, no number; the forecaster's own chance of this, stated with the estimate: 85%; the middle value lies beyond the limit too.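

With compound 2 and compound 4 both reported only as limits, bromo in place of methylamino on an aromatic carbon gives no readable step. The compounds shown leave open whether any change on the shared core yields a real number in this assay.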